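Swapping the Oxetane for a Cyclopropane

The source may hold more compounds than are shown below. What is called first, only, known or untested is meant among the compounds shown, and "the series" means these compounds.

Three compounds share one core and differ only in the group attached to a sulfonyl sulfur. In a functional assay on MIA PaCa-2 cells (Homo sapiens) for inhibition, read by MTT assay, with a stated time of 7 days (on this read-out lower numbers stand for stronger inhibition and higher numbers for weaker inhibition), compound 1 `CCN(CC)S(=O)(=O)c1ccc(S(=O)(=O)N2CCC[C@@H](C(=O)N3CCC(F)(F)CC3)C2)cc1` gives 16 nM, compound 2 `O=C([C@@H]1CCCN(S(=O)(=O)c2ccc(S(=O)(=O)N3CC[C@H](O)C3)cc2)C1)N1CCC(F)(F)CC1` gives 590 nM, and compound 3 `O=C([C@@H]1CCCN(S(=O)(=O)c2ccc(S(=O)(=O)C3COC3)cc2)C1)N1CCC(F)(F)CC1` gives 110 nM, so compound 3 stands second highest of the three numbers. Compound 4 `O=C([C@@H]1CCCN(S(=O)(=O)c2ccc(S(=O)(=O)C3CC3)cc2)C1)N1CCC(F)(F)CC1` carries the change (cyclopropyl in place of oxetan-3-yl on a sulfonyl sulfur). Among the measured compounds shown here, two measured steps bear on it: a 6.9-fold higher number from compound 1 to compound 3 (0.84 log units; beyond the scatter) and a 5.4-fold lower number from compound 2 to compound 3 (0.73 log units; beyond the scatter). The group with a hydroxyl gave the highest number and the group with no oxygen the lowest; cyclopropyl also contains no oxygen, so a modest move toward a lower number is expected, a 1.6-fold lower number from compound 3 to compound 4 (0.20 log units; within the scatter). Compound 4 is therefore estimated at 70 nM, within 25 nM to 200 nM.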

Compound 4, half-maximal inhibitory concentration: 26 nM
The estimate for compound 4 lay 2.7-fold (0.43 log units) above the measured number; the measured number falls inside the stated range.
By their numbers in this assay, from the lowest: compounds 1 and 4 (each within the scatter of the next); then compound 3; then compound 2.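

Cyclopropyl, which has no ring oxygen, gives a clearly lower number than oxetan-3-yl (a 4.2-fold lower number from compound 3 to compound 4 (0.63 log units; beyond the scatter)) and a far lower one than 3-hydroxypyrrolidin-1-yl (a 23-fold lower number from compound 2 to compound 4 (1.36 log units; beyond the scatter)). Against diethylamino, the step (a 1.6-fold higher number from compound 1 to compound 4 (0.21 log units; within the scatter)) stays within the scatter, so these two groups cannot be told apart here. A low number therefore does not require a nitrogen on this sulfonyl sulfur.

Going by these compounds, whether cyclobutyl, cyclopentyl or an open isopropyl chain would keep the number this low remains open. Nothing here gives a measured reason for these shifts.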